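A few compounds are considered here, and "the series" means these few. Any claim that something is new, unique, unknown or untested is made for them only; others in the source may bear on it.

Three compounds have been measured in a functional assay on SK-OV-3 cells (Homo sapiens) for antiproliferative activity, read by MTT assay; on this read-out lower numbers stand for stronger inhibition and higher numbers for weaker inhibition:

compound 1 `CCCOC(=O)N1CCCc2cc(S(=O)(=O)N3CC(c4ccccc4)NC3=O)ccc21`: 3920 nM
compound 2 `CC(C)COC(=O)N1CCCc2cc(S(=O)(=O)N3CC(c4ccccc4)NC3=O)ccc21`: 5650 nM
compound 3 `NC(=O)N1CCCc2cc(S(=O)(=O)N3CC(c4ccccc4)NC3=O)ccc21`: > 20000 nM, which is a limit of the assay and not a number.

Compound 2 has the higher of the two numbers, but its nearest neighbour, compound 1, sits within the scatter a 1.4-fold higher number from compound 1 to compound 2 (0.16 log units; within the scatter); the third value is only a limit (the limit of > 20000 nM in this assay, at which 1 of the 3 values shown sits).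

The unmeasured compound 4 `O=C(NC1CCCCC1)N1CCCc2cc(S(=O)(=O)N3CC(c4ccccc4)NC3=O)ccc21` differs from compound 2 at the carbonyl carbon: cyclohexylamino in place of isobutoxy on a carbonyl carbon. Going by the values given here, the one measured step that bears on this change is the one from compound 2 to compound 3, where amino replaced isobutoxy on the same carbonyl carbon and gave an at least 3.5-fold higher number from compound 2 to compound 3 (0.54 log units; beyond the scatter); the parallel step from compound 1 to compound 3 gave an at least 5.1-fold higher number from compound 1 to compound 3 (0.70 log units; beyond the scatter). Compound 4 keeps a carbamoyl rather than a carbamate, but carries a cyclohexyl group where compound 3 carries only hydrogen, so a smaller loss than that of compound 3 is expected. In this assay compound 4 is therefore expected to give 8000 nM, between 3000 nM and 20000 nM, a step of a 1.4-fold higher number from compound 2 to compound 4 (0.15 log units; within the scatter) that is expected to be modest or within the scatter.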

Compound 4, half-maximal inhibitory concentration: 1840 nM
For compound 4 the middle estimate is 4.3-fold (0.64 log units) above the measured one; measured number outside the range, below it.
By their numbers in this assay, from the lowest: compound 4; then compounds 1 and 2 (each within the scatter of the next). At a limit, above all of these: compound 3.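

In this assay, going by these compounds alone, the earlier compounds linked a nitrogen on this carbonyl carbon only with a loss, yet cyclohexylamino gives lower numbers than both carbamate groups, isobutoxy (a 3.1-fold lower number from compound 2 to compound 4 (0.49 log units; beyond the scatter)) and propoxy (a 2.1-fold lower number from compound 1 to compound 4 (0.33 log units; beyond the scatter)). The loss seen with amino therefore does not follow from a nitrogen at this place as such: what that nitrogen carries matters, as cyclohexyl in place of hydrogen shows (an at least 10-fold lower number from compound 3 to compound 4 (1.03 log units; beyond the scatter)). That last step is read against a limit and not against a number: the limit of > 20000 nM in this assay, at which 1 of the 4 values shown sits.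

The compounds shown leave open whether the gain belongs to the nitrogen link or to the cyclohexyl ring, which cyclohexyloxy on the same carbonyl carbon would separate. They also leave open how a phenyl, a cyclopentyl or an open hexyl chain on that nitrogen would compare.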